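Bromo Substitution on Compound 1: What to Expect

The compounds below may be only part of what the source reports. "The series", "measured", "known", "first", "only" and "open" are said of these compounds alone.

Compound 1 `Oc1ccc(/C=N/n2cnnc2)cc1` gives 2990 nM in an assay for inhibition of Alpha amylase (Homo sapiens), with a stated time of 10 min; a lower number here means a stronger inhibitor, a higher number a weaker inhibitor. Among the three measured compounds it holds the second highest number. Compound 3 `O=[N+]([O-])c1ccc(/C=N/n2cnnc2)cc1` gives 2360 nM, and the step is a 1.3-fold lower number from compound 1 to compound 3 (0.10 log units; within the scatter), so the two cannot be ordered. Compound 2 `CC(C)(C)c1ccc(/C=N/n2cnnc2)cc1` gives 6440 nM, and the step is a 2.2-fold higher number from compound 1 to compound 2 (0.33 log units; beyond the scatter). Between those two, the step is a 2.7-fold lower number from compound 2 to compound 3 (0.44 log units; beyond the scatter).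

Compound 4 `Oc1ccc(/C=N/n2cnnc2)cc1Br` differs from compound 1 by bromo in place of hydrogen on an aromatic carbon; the hydroxy group itself is retained. Within the data shown here, no measured step makes this exact change. Among the measured compounds shown here, the steps that bear on it replace the hydroxy group outright, and even those, a 2.2-fold higher number from compound 1 to compound 2 (0.33 log units; beyond the scatter) and a 1.3-fold lower number from compound 1 to compound 3 (0.10 log units; within the scatter), are modest or within the scatter, as is a 2.7-fold lower number from compound 2 to compound 3 (0.44 log units; beyond the scatter). Because compound 1 keeps its hydroxy group and the step of a 1.3-fold lower number from compound 1 to compound 3 (0.10 log units; within the scatter) shows how little the ring substituent moves this assay, the expected change is a 1.2-fold lower number from compound 1 to compound 4 (0.08 log units; within the scatter), likely not beyond the scatter. Compound 4 is therefore estimated at 2500 nM, with a range from 1000 nM to 6500 nM.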

Compound 4, half-maximal inhibitory concentration: 2270 nM
Compound 4: the middle estimate sits 1.1-fold (0.04 log units) above what was measured; low and high end bracket the measured number.
By their numbers in this assay, from the lowest: compounds 4, 3 and 1 (each within the scatter of the next); then compound 2.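

Among these compounds, compound 4 is the only compound here that keeps the hydroxy group and adds a second ring substituent: bromo, ortho to a hydroxy group and meta to a group of 7 heavy atoms. In this assay, among the compounds shown here, this gives a 1.3-fold lower number from compound 1 to compound 4 (0.12 log units; within the scatter), so a bromine atom at this position brings no change that can be read, whereas the earlier steps spoke only to replacing the hydroxy group. Nothing available explains why the number holds at this position.

A single bromo compound does not tell whether another group at this position, such as an amine or a carboxylic acid, would also leave the number unchanged. Nor do the compounds shown tell whether bromo would give the same result in a compound without the hydroxy group.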